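The source may hold more compounds than are shown below. What is called first, only, known or untested is meant among the compounds shown, and "the series" means these compounds.

In a functional assay on PC-3 cells (Homo sapiens) for antiproliferative activity, read by MTT assay, with a stated time of 72 h (on this read-out higher numbers stand for weaker inhibition and lower numbers for stronger inhibition), compound 1 `O=C(N/N=C/c1ccccc1)Nc1ccc(Oc2ccnc3[nH]ccc23)c(F)c1` gives 7940 nM and compound 2 `O=C(N/N=C/c1ccc(O)cc1O)Nc1ccc(Oc2ccnc3[nH]ccc23)c(F)c1` gives 13000 nM. Compound 3 `O=C(N/N=C/c1ccc(Br)cc1)Nc1ccc(Oc2ccnc3[nH]ccc23)cc1` is reported as "not active" (no number reported), so it stands without a number. Compound 4 `CN(C)CCn1cccc1/C=N/NC(=O)Nc1ccc(Oc2ccnc3[nH]ccc23)cc1` departs from compound 3 on the carbon with a double bond to nitrogen: 1-(2-(dimethylamino)ethyl)-1H-pyrrol-2-yl in place of 4-bromophenyl on a carbon with a double bond to nitrogen. For the measured compounds named here, only one measured step bears on this place, and a 1.6-fold higher number from compound 1 to compound 2 (0.21 log units; within the scatter) stays within the scatter. Going by the values given here, that step swaps a different group, and compound 3 offers no starting value, so no size of step from compound 3 can be derived. The expectation therefore rests on the values of compound 1 and compound 2 alone, with wide uncertainty. For compound 4 the expected value in this assay is 6000 nM, with an estimated range of 800 nM to 30000 nM.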

Compound 4, half-maximal inhibitory concentration: 3930 nM
Compound 4: middle estimate off by 1.5-fold (0.18 log units), on the high side; low and high end bracket the measured number.
By their numbers in this assay, from the lowest: compound 4; then compounds 1 and 2 (each within the scatter of the next).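

Compound 3 carries no number, so no step from it to compound 4 can be read, and nothing measured here offers an explanation for the result. The compounds shown leave open what 1-(2-(dimethylamino)ethyl)-1H-pyrrol-2-yl itself contributes to the activity of compound 4.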